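The source may report more compounds than this note shows. Statements on the series, on what has been measured and on what is new or still open speak of the compounds shown alone.

The three measured compounds share one core and differ only in the group on a saturated chain carbon bound to an oxygen on an aromatic ring. Compound 1 `Cc1cc(C)cc(COc2ccc(-c3cc(CN4CCN(Cc5ccc(C(F)(F)F)cc5)CC4)no3)cc2)c1` carries a 3,5-dimethylphenyl there; in a functional assay on Mahlavu cells (Homo sapiens) for antiproliferative activity, read by sulforhodamine B assay, with a stated time of 72 h (on this read-out lower numbers stand for stronger inhibition and higher numbers for weaker inhibition), compound 1 gives 6000 nM. Compound 2 `N#Cc1ccccc1COc1ccc(-c2cc(CN3CCN(Cc4ccc(C(F)(F)F)cc4)CC3)no2)cc1` carries a 2-cyanophenyl and gives 3500 nM in this assay. Compound 3 `Fc1ccccc1COc1ccc(-c2cc(CN3CCN(Cc4ccc(C(F)(F)F)cc4)CC3)no2)cc1` carries a 2-fluorophenyl and gives 3100 nM in this assay. Compound 3 shows the lowest of the three numbers, yet all three sit within the scatter of one another: a 1.9-fold lower number from compound 1 to compound 3 (0.29 log units; within the scatter), a 1.7-fold lower number from compound 1 to compound 2 (0.23 log units; within the scatter), and a 1.1-fold lower number from compound 2 to compound 3 (0.05 log units; within the scatter).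

Compound 4 `COc1cccc(COc2ccc(-c3cc(CN4CCN(Cc5ccc(C(F)(F)F)cc5)CC4)no3)cc2)c1` differs from compound 3 by 3-methoxyphenyl in place of 2-fluorophenyl on a saturated chain carbon bound to an oxygen on an aromatic ring. Every step measured so far at this place, whether a swap of the whole aryl group or a swap of one substituent for another, has stayed within the scatter, and nothing among the three compounds points to a substituent here moving the number beyond it. The expected step is therefore small, a 1.3-fold higher number from compound 3 to compound 4 (0.11 log units; within the scatter), with no direction established. Compound 4 is estimated at 4000 nM in this assay, with a range from 1500 nM to 10000 nM.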

Compound 4, half-maximal inhibitory concentration: 1400 nM
Compound 4: middle estimate off by 2.9-fold (0.46 log units), on the high side; the whole stated range lies above it.
By their numbers in this assay, from the lowest: compound 4; then compounds 3, 2 and 1 (each within the scatter of the next).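

In this assay, among the compounds shown here, this is the first change at the saturated chain carbon bound to an oxygen on an aromatic ring to carry the number beyond the scatter, and it does so against every earlier group: 3-methoxyphenyl in place of 2-fluorophenyl (a 2.2-fold lower number from compound 3 to compound 4 (0.35 log units; beyond the scatter)), in place of 2-cyanophenyl (a 2.5-fold lower number from compound 2 to compound 4 (0.40 log units; beyond the scatter)) and in place of 3,5-dimethylphenyl (a 4.3-fold lower number from compound 1 to compound 4 (0.63 log units; beyond the scatter)). The position therefore does respond to the choice of aryl group, although each of these steps remains modest and compound 4 alone stands clear of the other three, which remain within the scatter of their neighbours in the ranking. No measurement shown here offers an explanation for this gain.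

Because 2-fluorophenyl and 3-methoxyphenyl differ in both the substituent and the number in the group's name, the compounds shown cannot separate what the methoxy group contributes from what its placement contributes. As far as these compounds go, it remains open whether 2-methoxyphenyl, 3-fluorophenyl or 3-ethoxyphenyl would follow compound 4 or stay with compounds 1, 2 and 3, and whether a 3-aminophenyl or 3-carboxyphenyl would extend the step.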